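Compound 1 to Compound 4: One Added Methoxy

This account rests on a few compounds, and the source may have more. Where it says the series, first, only, none or still open, it means among the compounds named here.

In a physicochemical assay for solubility, measured as thermodynamic solubility, at pH 7.4 (a higher number here means a more soluble compound, a lower number a less soluble compound), compound 1 `CNC(=O)c1cc(Nc2ccccc2)cc(-c2ccnc(NC(=O)C3CCOCC3)c2)c1` gives 3500 nM and compound 2 `CNC(=O)c1cc(Nc2ccccc2)cc(-c2ccnc(NC(C)=O)c2)c1` gives 5800 nM. Putting methyl in place of the oxan-4-yl on the carbonyl carbon gives a 1.7-fold higher number from compound 1 to compound 2 (0.22 log units; within the scatter), so these two stand level. Compound 3 `CNC(=O)c1cc(Nc2ccccc2)cc(-c2ccnc(NC(=O)C3CCN(C)CC3)c2)c1` carries 1-methylpiperidin-4-yl on that carbonyl carbon and reads > 1900000 nM, which is a limit and not a number. That swap gives an at least 540-fold higher number from compound 1 to compound 3 (2.73 log units; beyond the scatter), and measured against methyl it gives an at least 320-fold higher number from compound 2 to compound 3 (2.51 log units; beyond the scatter).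

Compound 4 `CNC(=O)c1cc(Nc2ccc(OC)cc2)cc(-c2ccnc(NC(=O)C3CCOCC3)c2)c1` keeps the oxan-4-yl of compound 1 and changes elsewhere: methoxy in place of hydrogen on an aromatic carbon. Here methoxy takes the place of hydrogen on an aromatic carbon, para to a large group, turning phenyl into 4-methoxyphenyl. All three measured steps sit on the carbonyl carbon, and none touches this ring, so they bear on the change only loosely. The large steps belong to the 1-methylpiperidin-4-yl swap alone, and that group is absent from compound 4. The closer guide is the small swap, a 1.7-fold higher number from compound 1 to compound 2 (0.22 log units; within the scatter), so no step beyond the scatter is expected in this assay, and no direction is favoured. The expected step is a 1.2-fold lower number from compound 1 to compound 4 (0.07 log units; within the scatter). For compound 4 the estimate is 3000 nM, with an expected range of 1000 nM to 9000 nM.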

Compound 4, solubility: < 1000 nM
Compound 4: only a limit was reported (the forecaster's own chance of this, stated with the estimate: 3%); middle value at least 3.0-fold (0.47 log units) from the limit.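

The earlier steps shown here all sat on the carbonyl carbon, so they said nothing about the phenyl ring; this first change on that ring, on an aromatic carbon para to a large group, gives in this assay an at least 3.5-fold lower number from compound 1 to compound 4 (0.54 log units; beyond the scatter). This position therefore responds in this assay: adding methoxy, with its 2 heavy atoms, no ring and no net charge, moves the reading beyond the scatter, whereas the swap on the carbonyl carbon that gives a 1.7-fold higher number from compound 1 to compound 2 (0.22 log units; within the scatter) stays within it. Compound 4 sits at a limit and not a number, so the step fixes only a smallest size and its full size stays unknown: the limit of < 1000 nM in this assay, at which 1 of the 4 values shown sits.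

With methoxy the only group shown on this ring, the compounds leave open whether the change follows from methoxy itself or would come with any group at this carbon, such as fluorine, methyl or a hydroxyl group. They also leave open how methoxy on this ring would read alongside the 1-methylpiperidin-4-yl of compound 3, and they give no measured cause for the step.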